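From compound 2 to compound 3: one group exchanged

The source may hold more compounds than are shown below. What is called first, only, known or untested is meant among the compounds shown, and "the series" means these compounds.

- compound 1 `CC(=O)N[C@@H]1CCC[C@H](C(=O)Nc2cc(-c3cnc4n3CCCC4)c(Cl)cn2)C1`: 600000 nM
- compound 2 `CC(=O)N[C@@H]1CCC[C@H](C(=O)Nc2cc(-c3cnn4c3CN(C)CC4)c(Cl)cn2)C1`: 870000 nM

In a physicochemical assay for solubility, in phosphate buffer, at pH 7.4 (on this read-out lower numbers stand for lower solubility and higher numbers for higher solubility), compound 2 gives 870000 nM, which lies within the usual scatter of compound 1. Compound 3 `CC(=O)N[C@@H]1CCC[C@H](C(=O)Nc2cc(-c3cnc4n3CC(C)(C)C4)c(Cl)cn2)C1` keeps the shared core but exchanges one group, on an aromatic carbon ortho to a chloro group: a group of 10 heavy atoms (8 carbon, 2 nitrogen; one five-membered non-aromatic ring with 1 hetero atom, one five-membered aromatic ring with 2 hetero atoms) in place of a group of 10 heavy atoms (7 carbon, 3 nitrogen; one five-membered aromatic ring with 2 hetero atoms, one six-membered non-aromatic ring with 2 hetero atoms), on an aromatic carbon. Going by the values given here, one measured step bears on this, a different exchange at the same place: a 1.5-fold higher number from compound 1 to compound 2 (0.16 log units; within the scatter). Among the compounds with values here, with only that small step as a guide, no change beyond the scatter is expected in this assay. For compound 3 the estimated value is 700000 nM, with an expected range of 300000 nM to 1400000 nM. This estimate means an expected 1.2-fold lower number from compound 2 to compound 3 (0.09 log units; within the scatter).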

Compound 3, solubility: 280000 nM
Compound 3: middle estimate off by 2.5-fold (0.40 log units), on the high side, and the stated range ends above it.
By their numbers in this assay, from the lowest: compound 3; then compounds 1 and 2 (each within the scatter of the next).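

In this assay this position on the shared core proves sensitive to the group placed there: the exchange gives a 3.1-fold lower number from compound 2 to compound 3 (0.49 log units; beyond the scatter) and a 2.1-fold lower number from compound 1 to compound 3 (0.33 log units; beyond the scatter) and so leaves compound 3 the lowest of the three, though both steps are modest. The earlier compounds shown here showed no such separation. No measurement here gives a reason for this lower number. Still open, going by these compounds, is whether the five-membered non-aromatic ring of compound 3 would give the same number without its methyl groups, or with a hydroxyl or an amine on that ring.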